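Removing the benzylidene arm: an amino group on the core

The source may report more compounds than this note shows. Statements on the series, on what has been measured and on what is new or still open speak of the compounds shown alone.

Of the compounds shown here, three sharing one core have been tested in a functional assay on the whole organism (strain albino) for inhibition, with Rattus norvegicus as the target, read by paw edema, with stated times of 1 h and 3 h, at a dose of 20 mmol/kg by the intraperitoneal route; a lower number here means a weaker effect, a higher number a stronger effect of the compound at the dose given. Compound 1, `N#CC1=C(NC(=O)c2ccccc2O)N(c2ccccc2)C(=O)N2CCCCC(N3CCCC3)C12`, gives 65.4%. Compound 2, `N#CC1=C(/N=C/Nc2ccc([N+](=O)[O-])cc2)N(c2ccccc2)C(=O)N2CCCCC(N3CCCC3)C12`, gives 85.6%. Compound 3, `N#CC1=C(/N=C/c2ccccc2)N(c2ccccc2)C(=O)N2CCCCC(N3CCCC3)C12`, gives 84%, the second highest of the three numbers; compound 2 lies nearest, and the two sit within the scatter of each other, while compound 1 is furthest, lower beyond the scatter.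

Compound 4, `N#CC1=C(N)N(c2ccccc2)C(=O)N2CCCCC(N3CCCC3)C12`, is made from compound 3 by a single change: one nitrogen atom in place of a group of 8 heavy atoms (7 carbon, 1 nitrogen; one six-membered aromatic ring of carbon only), on a double-bonded ring carbon. Going by the values given here, no measured step matches this change. The steps that touch the same double-bonded ring carbon are a number 18.6 percentage points higher from compound 1 to compound 3 (beyond the scatter) and a number 20.2 percentage points higher from compound 1 to compound 2 (beyond the scatter); both swapped one sizeable group for another, and the two imine-bearing compounds 2 and 3 came out higher than the amide-bearing compound 1. Compound 4 instead leaves only an amino group, a situation none of the three covers, so the expectation must be wide. A modest fall is expected, a number 22 percentage points lower from compound 3 to compound 4 (beyond the scatter), because compound 1, the only other variant at this carbon, gave 65.4%. Compound 4 is therefore estimated at 62%, with a range from 45% to 80%.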

Compound 4, a percentage reported as inhibition, in the whole organism at one dose (the size of the read-out at that dose, not a potency): 90.1%
Compound 4: middle estimate off by 28.1 percentage points, on the low side; the measured number lies above the stated range.
By their numbers in this assay, from the lowest: compound 1; then compounds 3, 2 and 4 (each within the scatter of the next).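

In this assay, cutting the arm on the double-bonded ring carbon down to a bare amino group does not lose the effect: a number 6.1 percentage points higher from compound 3 to compound 4 (within the scatter) and a number 4.5 percentage points higher from compound 2 to compound 4 (within the scatter), so neither large arm is required for this read-out at the dose given. The picture differs against the amide-bearing compound, with a number 24.7 percentage points higher from compound 1 to compound 4 (beyond the scatter), which leaves compound 1 as the only one of the four set apart from the rest. Nothing measured here explains that difference.

Going by these compounds, it remains open whether a methylamino group or a small acetyl amide on this nitrogen would stay with compound 4 or fall towards compound 1. A plain benzoyl amide would show whether the hydroxyl group of the (2-hydroxyphenyl)carbonyl group goes with the lower number, and a single dose cannot show how potency compares.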